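Ethoxy ester replacing a methoxy(methyl)amide in nucleoside ureas

The compounds below may be only part of what the source reports. "The series", "measured", "known", "first", "only" and "open" are said of these compounds alone.

Of the compounds shown here, two built on a shared core have been measured in a functional assay on Malme-3M cells (Homo sapiens) for antiproliferative activity; on this read-out lower numbers stand for stronger inhibition of growth and higher numbers for weaker inhibition of growth. Compound 1 `CCOC(=O)C[C@H]1[C@@H](O[Si](C)(C)C(C)(C)C)[C@H](n2cnc3c(NC(=O)Nc4ccccc4)ncnc32)O[C@@H]1COC(=O)NC` gives 3.34 nM in this assay. Compound 2 `CNC(=O)NC[C@H]1O[C@@H](n2cnc3c(NC(=O)Nc4ccccc4)ncnc32)[C@H](O[Si](C)(C)C(C)(C)C)[C@@H]1CC(=O)N(C)OC` gives 11.4 nM in this assay, the higher of the two numbers, and the gap between compound 1 and compound 2 lies beyond the usual scatter. Compound 3 `CCOC(=O)C[C@H]1[C@@H](O[Si](C)(C)C(C)(C)C)[C@H](n2cnc3c(NC(=O)Nc4ccccc4)ncnc32)O[C@@H]1CNC(=O)NC` has not yet been measured. It differs from compound 2 at a carbonyl carbon whose other neighbours are a saturated chain carbon: ethoxy in place of methoxy(methyl)amino on a carbonyl carbon. Within the data shown here, the resulting ethoxycarbonyl group is the one also present in compound 1, which gives 3.34 nM in this assay, so the step of a 2.3-fold lower number from compound 2 to compound 3 (0.36 log units; beyond the scatter) is expected to move the number downward by a modest amount, somewhat beyond the scatter. Compound 3 is accordingly estimated at 5 nM in this assay, within a range from 2 nM to 14 nM.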

Compound 3, concentration for 50% growth inhibition: 10.3 nM
Compound 3: the middle estimate sits 2.1-fold (0.31 log units) below what was measured, and the stated range covers the measured number.
By their numbers in this assay, from the lowest: compound 1; then compounds 3 and 2 (each within the scatter of the next).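

The step of a 1.1-fold lower number from compound 2 to compound 3 (0.04 log units; within the scatter) in this assay leaves compound 2 and compound 3 indistinguishable, so on this carbonyl carbon ethoxy and methoxy(methyl)amino read alike. The ethoxycarbonyl group shared with compound 1 therefore does not carry that compound's lower number on its own, whereas the step of a 3.1-fold higher number from compound 1 to compound 3 (0.49 log units; beyond the scatter) comes with a change elsewhere, (methylcarbamoyl)amino in place of (methylcarbamoyl)oxy on a saturated chain carbon bound to a saturated ring carbon. Nothing measured here gives a reason for either step. Still open, as far as these compounds go, is whether this carbonyl carbon tolerates everything equally, since a carboxylic acid, a simple primary amide or a longer chain in place of ethoxy could read quite differently. From the compounds shown here alone, it is also open whether the (methylcarbamoyl)oxy advantage would hold with methoxy(methyl)amino on the carbonyl carbon.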